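Cyclic Amine Side Chains on a Decylphenyl Oxadiazole Scaffold

This account rests on a few compounds, and the source may have more. Where it says the series, first, only, none or still open, it means among the compounds named here.

Three compounds sharing the same core were tested in an assay on HeLa cells for inhibition of sphingosine-1-phosphate transporter SPNS2 (Mus musculus), read by LC-MS, tested at 2 uM; a higher number here means more inhibition at the concentration tested (going by the name of the read-out), a lower number less inhibition. Compound 1 `CCCCCCCCCCc1ccc(-c2noc(CC3CNC3)n2)cc1` gives 63%, compound 2 `CCCCCCCCCCc1ccc(-c2noc(C3CCNC3)n2)cc1` gives 26%, and compound 3 `CCCCCCCCCCc1ccc(-c2noc([C@@H](N)CCCCN)n2)cc1` gives 43%. Compound 3 therefore stands second highest of the three: its nearest neighbour is compound 2, with a number 17 percentage points higher from compound 2 to compound 3 (beyond the scatter), while its furthest is compound 1, with a number 20 percentage points lower from compound 1 to compound 3 (beyond the scatter). Compound 4 `CCCCCCCCCCc1ccc(-c2noc(CCCN3CCCC3)n2)cc1` has not yet been measured. It differs from compound 3 in one place: 3-(pyrrolidin-1-yl)propyl in place of 1,5-diaminopentyl on an aromatic carbon.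

Two of the measured steps bear on this change, as both start or end at compound 3. Replacing pyrrolidin-3-yl by 1,5-diaminopentyl gave a number 17 percentage points higher from compound 2 to compound 3 (beyond the scatter), whereas replacing (azetidin-3-yl)methyl by 1,5-diaminopentyl gave a number 20 percentage points lower from compound 1 to compound 3 (beyond the scatter). Among the compounds with values here, a cyclic amine group thus sat either below or above the open diamine, depending on how it was attached, and no measured compound carries 3-(pyrrolidin-1-yl)propyl, with no hydrogen-bond donors. The direction of the step is therefore uncertain, and only a change within the scatter is expected on balance, with a wide range in either direction. On that basis compound 4 is estimated at 40% in this assay, between 15% and 65%, which would mean an expected step of a number 3 percentage points lower from compound 3 to compound 4 (within the scatter).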

Compound 4, a percentage reported as inhibition, at one concentration (the size of the read-out at that concentration, not a potency): 3%
The estimate for compound 4 lay 37 percentage points above the measured number; the measured number lies below the stated range.
By their numbers in this assay, from the lowest: compound 4; then compound 2; then compound 3; then compound 1.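

In this assay, the change from 1,5-diaminopentyl to 3-(pyrrolidin-1-yl)propyl on this aromatic carbon gave a number 40 percentage points lower from compound 3 to compound 4 (beyond the scatter) and left compound 4 the lowest of the four compounds, so this position does not accept every amine-bearing side chain equally. The same group also gave a number 23 percentage points lower from compound 2 to compound 4 (beyond the scatter) and a number 60 percentage points lower from compound 1 to compound 4 (beyond the scatter) when set against the two side chains with a saturated nitrogen ring, which shows that such a ring alone does not secure a high number in this series. The change replaces 2 hydrogen-bond donors with 0 and adds a five-membered non-aromatic ring, but no supporting data tie the fall to either difference or to any other.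

The compounds shown leave open whether the low number follows from the pyrrolidine ring on the chain end or from the propyl linker, since a simple 3-aminopropyl or 3-(dimethylamino)propyl group does not appear among them. They also leave open whether a piperidine at the end of the same chain, or a free amine restored on that ring, would bring the number back up.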